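From compound 1 to compound 4: one group exchanged

The source may hold more compounds than are shown below. What is called first, only, known or untested is meant among the compounds shown, and "the series" means these compounds.

Measured so far in an ADME assay on Caco-2 cells (Homo sapiens) for permeability, in the apical to basolateral direction, at pH 7.4 (a higher number here means that the compound crosses the layer faster, a lower number that the compound crosses the layer more slowly), are these compounds:
compound 1 `Cc1csc(C(=O)N[C@H]2CN(S(=O)(=O)c3ccccc3)C[C@@H]2C(=O)N[C@H]2CCCNC2)n1` gives 0.18 10^-6 cm/s
compound 2 `Cc1nc(-c2cccc(C(F)(F)F)c2)sc1C(=O)N[C@H]1CN(S(=O)(=O)c2ccccc2)C[C@@H]1C(=O)N[C@H]1CCCNC1` gives 0.46 10^-6 cm/s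
compound 3 `Cc1oc(-c2ccc(C(F)(F)F)cc2)nc1C(=O)N[C@H]1CN(S(=O)(=O)c2ccccc2)C[C@@H]1C(=O)N[C@H]1CCCNC1` gives 0.1 10^-6 cm/s

Compound 1 lies within the scatter of compound 3, while compound 2 reads higher than compound 1, beyond the scatter. Compound 4 `O=C(N[C@H]1CN(S(=O)(=O)c2ccccc2)C[C@@H]1C(=O)N[C@H]1CCCNC1)c1cc(-c2ccc(Cl)cc2)on1` has no value yet. Its change from compound 1 is 5-(4-chlorophenyl)-1,2-oxazol-3-yl in place of 4-methyl-1,3-thiazol-2-yl on a carbonyl carbon. Among the compounds with values here, no measured pair shows this change alone. Compound 2 (0.46 10^-6 cm/s) and compound 3 (0.1 10^-6 cm/s) also carry a second aromatic ring in that group, yet only compound 2 stands beyond the scatter from compound 1. No step beyond the scatter is therefore expected in this assay for this change. The expected step is small (a 1.1-fold higher number from compound 1 to compound 4 (0.05 log units; within the scatter)). Compound 4 is estimated at 0.2 10^-6 cm/s (range 0.07 10^-6 cm/s to 0.6 10^-6 cm/s).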

Compound 4, apparent permeability: < 0.01 10^-6 cm/s
Compound 4: a limit, no number; the forecaster's own chance of this, stated with the estimate: 8%; middle value at least 20-fold (1.30 log units) away from the limit.
By their numbers in this assay, from the lowest: compounds 3 and 1 (each within the scatter of the next); then compound 2. At a limit, below all of these: compound 4.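

In this assay compound 4 gives < 0.01 10^-6 cm/s, which is a limit of the assay and not a number. The exchange on the carbonyl carbon is a large step, an at least 18-fold lower number from compound 1 to compound 4 (1.25 log units; beyond the scatter), so this position is not indifferent to the group that enters there. A second aromatic ring in that group does not by itself bring a value to where compound 4 stands: compound 2 gives 0.46 10^-6 cm/s, and compound 3 gives 0.1 10^-6 cm/s. The compounds shown do not separate the part played by the chlorine from that of the 1,2-oxazole ring. From the compounds shown here alone, what a methoxy group or an amine in place of the chlorine would give also stays open.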